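The source may hold more compounds than are shown below. What is called first, only, known or untested is meant among the compounds shown, and "the series" means these compounds.

Compound 1 `Cn1cc(-c2ccc3nnc(Sc4ccc5ncc(N6CCC(N)C6)cc5c4)n3c2)cn1` is the starting point of this account. In an ADME assay on cytosol from liver for pharmacokinetics, with aldehyde oxidase 1 (Macaca fascicularis) as the target, read by LC-MS, with a stated time of 120 min, tested at 1 uM (on this read-out lower numbers stand for a shorter-lived compound and higher numbers for a longer-lived compound), compound 1 gives > 8.33 h, which is a limit of the assay rather than a number. Two measured relatives replace the 3-aminopyrrolidin-1-yl group on the aromatic carbon. Compound 2 `Cn1cc(-c2ccc3nnc(Sc4ccc5ncc(NC6CCOC6)cc5c4)n3c2)cn1` carries (oxolan-3-yl)amino there and gives 0.05 h in this assay. Compound 3 `Cn1cc(-c2ccc3nnc(Sc4ccc5ncc(NCCO)cc5c4)n3c2)cn1` carries (2-hydroxyethyl)amino and gives 0.152 h in this assay. Both measured steps downward are large: an at least 160-fold lower number from compound 1 to compound 2 (2.22 log units; beyond the scatter) and an at least 54-fold lower number from compound 1 to compound 3 (1.73 log units; beyond the scatter), while a 3.0-fold higher number from compound 2 to compound 3 (0.48 log units; beyond the scatter) is a modest step between the two short-lived compounds.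

Compound 4 `Cn1cc(-c2ccc3nnc(Sc4ccc5ncc(NC6COC6)cc5c4)n3c2)cn1` has not yet been measured. It differs from compound 1 by (oxetan-3-yl)amino in place of 3-aminopyrrolidin-1-yl on an aromatic carbon. For the measured compounds named here, this change is a close relative of the one leading to compound 2, where an (oxolan-3-yl)amino group entered at the same aromatic carbon and the value fell far; the step leading to compound 3 points the same way. The expectation for compound 4 is therefore a large drop in this assay, and the step of an at least 100-fold lower number from compound 1 to compound 4 (2.01 log units; beyond the scatter) is the estimate that follows. Compound 4 is expected to give 0.08 h in this assay, with a range from 0.03 h to 0.3 h.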

Compound 4, half-life: 0.05 h
Estimate against measurement, compound 4: 1.6-fold (0.20 log units) above, within the range that was stated.
By their numbers in this assay, from the lowest: compounds 2 and 4 (each within the scatter of the next); then compound 3. At a limit, above all of these: compound 1.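

In this assay, the size of the ring on the nitrogen does not separate the two cyclic ethers: the four-membered oxetan-3-yl in place of the five-membered oxolan-3-yl gives no change at the digits printed from compound 2 to compound 4 (within the scatter). The open-chain 2-hydroxyethyl group stays apart from the four-membered ring, with a 3.0-fold lower number from compound 3 to compound 4 (0.48 log units; beyond the scatter), so at this aromatic carbon the ring and the chain are told apart only by a modest step. All three oxygen-bearing groups now lie far from 3-aminopyrrolidin-1-yl, but an at least 160-fold lower number from compound 1 to compound 4 (2.22 log units; beyond the scatter) gives only a bound on the size of that step, and compound 1 stands at a limit of the assay: the limit of > 8.33 h in this assay, at which 1 of the 4 values shown sits.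

The compounds shown leave open which part of 3-aminopyrrolidin-1-yl goes with the long half-life, its free amine or its ring nitrogen on the aromatic carbon, as compound 2, compound 3 and compound 4 each differ from compound 1 in both at once. From the compounds shown here alone, a plain pyrrolidin-1-yl group or a (pyrrolidin-3-yl)amino group would bear on that question, while the true half-life of compound 1 remains unknown.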